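Ester swap across two cores: working notes

The source may hold more compounds than are shown below. What is called first, only, known or untested is meant among the compounds shown, and "the series" means these compounds.

The compounds are compared in a functional assay on B16 cells (Mus musculus) for cytotoxicity, read by MTT assay, with a stated time of 48 h; on this read-out higher numbers stand for weaker inhibition and lower numbers for stronger inhibition. Compound 1 `C#Cc1ccc(NC(=O)c2cn(CC(=O)OCC)nn2)cc1` carries an ethoxycarbonyl group on a saturated chain carbon bound to an aromatic nitrogen. In this assay compound 1 gives only a limit of the assay, > 100000 nM. Compound 2 `C#Cc1ccc(NC(=O)c2cn(CCOC(C)=O)nn2)cc1` differs from it by acetoxymethyl in place of ethoxycarbonyl on a saturated chain carbon bound to an aromatic nitrogen. In this assay compound 2 gives 79000 nM. The step of an at least 1.2-fold lower number from compound 1 to compound 2 (0.10 log units; that floor lies within the scatter) rests on the limit (the limit of > 100000 nM in this assay, at which 1 of the 3 values shown sits), so only a floor is known for its size.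

Compound 3 `CCOC(=O)Cn1cc(-c2cccc(NC(=O)c3cn(CCOC(C)=O)nn3)c2)nn1` has a different core; the difference between the cores of compound 1 and compound 3 is not broken down here. In this assay compound 3 gives 63000 nM, which sits within the scatter of compound 2.

Compound 4 `CC(=O)OCCn1cc(C(=O)Nc2cccc(-c3cn(CCOC(C)=O)nn3)c2)nn1` is not yet measured. From compound 3 it differs by acetoxymethyl in place of ethoxycarbonyl on a saturated chain carbon bound to an aromatic nitrogen, the same change as from compound 1 to compound 2. Compound 4 is expected to show a step of a 1.3-fold lower number from compound 3 to compound 4 (0.10 log units; within the scatter), resting on the floor given by an at least 1.2-fold lower number from compound 1 to compound 2 (0.10 log units; that floor lies within the scatter). Compound 4 is therefore estimated at 50000 nM in this assay, with a range from 25000 nM to 100000 nM.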

Compound 4, half-maximal inhibitory concentration: > 100000 nM
Compound 4: a limit, no number; the forecaster's own chance of this, stated with the estimate: 10%; middle value at least 2.0-fold (0.30 log units) away from the limit.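

In this assay compound 4 gives > 100000 nM, which is a limit of the assay and not a number. Acetoxymethyl in place of ethoxycarbonyl, on a saturated chain carbon bound to an aromatic nitrogen, gives an at least 1.5-fold higher number from compound 3 to compound 4 (0.20 log units; that floor lies within the scatter), so the change on this core is known only as a floor, and setting it beside the earlier step does not settle whether the change carries over from one core to the other: the same change on two cores in this assay, an at least 1.2-fold lower number (0.10 log units; that floor lies within the scatter) from compound 1 to compound 2 and an at least 1.5-fold higher number (0.20 log units; that floor lies within the scatter) from compound 3 to compound 4; the limit leaves it open whether they differ Neither step has a known size, so the series shows neither that the change transfers nor that it fails to transfer, and some of the compounds give no number: the limit of > 100000 nM in this assay, at which 2 of the 4 values shown sit.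

From the compounds shown here alone, it remains open whether an amine or a carboxylic acid in place of either ester, or a longer chain in place of 2-acetoxyethyl, would give numbers rather than limits in this assay. Going by these compounds, it also remains open how the change behaves on a core where both partners give numbers.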